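A few compounds are considered here, and "the series" means these few. Any claim that something is new, unique, unknown or untested is made for them only; others in the source may bear on it.

Three compounds share one core and differ only on the pendant benzene ring. In an assay on isolated protein for inhibition of Amine oxidase [flavin-containing] A (Homo sapiens), read by fluorescence and spectrophotometry, with a stated time of 20 min (a higher number here means a weaker inhibitor, a lower number a stronger inhibitor), compound 1 `O=C1/C(=C/c2ccccc2)Cc2ccc(O)cc21` gives 440 nM. Compound 2 `O=C1/C(=C/c2cccc(F)c2)Cc2cc(O)ccc21`, which carries a fluoro on that ring, gives 458 nM in this assay. Compound 3 `O=C1/C(=C/c2ccc(F)cc2)Cc2cc(O)ccc21` gives 679 nM in this assay. Compound 2 stands within the usual scatter of both compound 1 and compound 3, so the three numbers cannot be told apart. Compound 4 `Cc1cccc(/C=C2\Cc3cc(O)ccc3C2=O)c1` has not yet been measured; it differs from compound 2 by methyl in place of fluoro on an aromatic carbon. Among the measured compounds shown here, no measured pair shows what this swap does. Fluoro and methyl each count as one heavy atom, so no step beyond the scatter is expected in either direction. Compound 4 is estimated at 420 nM, with a range from 200 nM to 900 nM. The expected step in this assay is a 1.1-fold lower number from compound 2 to compound 4 (0.04 log units; within the scatter).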

Compound 4, half-maximal inhibitory concentration: 860 nM
The estimate for compound 4 lay 2.0-fold (0.31 log units) below the measured number; the range from low to high includes it.
By their numbers in this assay, from the lowest: compounds 1, 2, 3 and 4 (each within the scatter of the next).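

In this assay, among the compounds shown here, methyl in place of fluoro on this aromatic carbon gives a 1.9-fold higher number from compound 2 to compound 4 (0.27 log units; within the scatter), the first step here between compounds that differ in only one place. At this position, then, the two groups cannot be told apart, as the step stays within the usual scatter. No available evidence bears on this result. On these data alone, whether an amine, a carboxylic acid or a longer chain at this position would give a step beyond the scatter remains open.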